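The source may hold more compounds than are shown below. What is called first, only, known or untested is meant among the compounds shown, and "the series" means these compounds.

Notes on the series. Compound 1 `CN1C(=O)COc2cc(Nc3cc4c(cn3)ncn4CC3CC3)cnc21` is the starting point of the set. In an ADME assay on microsomes from liver (Rattus norvegicus) for metabolic stability (a higher number here means that the compound lasts longer, a lower number that the compound disappears faster), compound 1 reaches only a limit of the assay, > 1.66 h, so no number is known for it. Compound 2 `Cc1nc(Nc2cnc3c(c2)OCC(=O)N3C)cc2c1ncn2CC1CC1` carries methyl in place of hydrogen on an aromatic carbon. In this assay compound 2 also sits at a limit, > 1.66 h. The step that the two limits leave unreadable from compound 1 to compound 2 therefore cannot be read, as both values sit at the limit of > 1.66 h in this assay, at which 2 of the 3 values shown sit. Compound 3 `CN1C(=O)COc2cc(Nc3cc4c(cc3F)ncn4CC3CC3)cnc21` has a different core from compound 1; the difference between the two cores is not broken down here. In this assay, for the measured compounds named here, compound 3 gives 0.283 h, the only number in the set. Compound 4 `Cc1c(F)c(Nc2cnc3c(c2)OCC(=O)N3C)cc2c1ncn2CC1CC1` is not yet measured and differs from compound 3 by methyl in place of hydrogen on an aromatic carbon. This is the same kind of change as that from compound 1 to compound 2, not the same: in compound 2 the methyl enters on a six-membered aromatic ring with 1 nitrogen, next to the ring nitrogen, whereas in compound 4 it enters on a six-membered aromatic ring of carbon only, ortho to a fluoro group. In this assay the expected step of a 1.2-fold higher number from compound 3 to compound 4 (0.09 log units; within the scatter) is small. This rests on the earlier instance of the same kind of change, a step that the two limits leave unreadable from compound 1 to compound 2, which leaves no readable size, and on compound 3 giving 0.283 h as a number rather than a limit, so that a modest shift either way would still be read. Compound 4 is estimated at 0.35 h, most likely between 0.15 h and 0.9 h.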

Compound 4, half-life: 0.917 h
For compound 4 the middle estimate is 2.6-fold (0.42 log units) below the measured one; measured number above the stated range.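

In this assay, methyl in place of hydrogen on an aromatic carbon gives a 3.2-fold higher number from compound 3 to compound 4 (0.51 log units; beyond the scatter), so on the core of compound 3 this change goes with a longer half-life, with the methyl on a six-membered aromatic ring of carbon only and ortho to a fluoro group. The same kind of change on the core of compound 1 cannot be read, so the size of the step on the two cores cannot be compared: the limit of > 1.66 h in this assay, at which 2 of the 4 values shown sit. The series therefore holds one readable instance of this change, which shows its direction and size on one core only and does not show that it carries over to another, the more so as the methyl of compound 2 enters a ring with 1 nitrogen and the methyl of compound 4 a ring of carbon only.

The compounds shown leave open whether a different group on the same aromatic carbon, such as ethyl or methoxy, would give a step of like direction in this assay. Also open, going by these compounds, is how far the step depends on the fluoro group, and what a chloro group or a nitrile in its place would give on the core of compound 3.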